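Cytotoxicity notes: amide tail variation on the shared core

A few compounds are considered here, and "the series" means these few. Any claim that something is new, unique, unknown or untested is made for them only; others in the source may bear on it.

Compound 1 `CCCCCC(=O)NCCCN1CCN(CCCNc2ccnc3cc(Cl)ccc23)CC1` carries a pentylcarbonyl amide on the shared core; in an ADME assay on L6 cells (Rattus norvegicus) for cytotoxicity (on this read-out lower numbers stand for stronger inhibition and higher numbers for weaker inhibition), compound 1 gives "not determined" (no result reported), so no single number stands for it. Two measured neighbours anchor the series. Among the measured compounds shown here, compound 2 `CCc1ccc(C(=O)NCCCN2CCN(CCCNc3ccnc4cc(Cl)ccc34)CC2)cc1` gives 3900 nM in this assay, and compound 3 `O=C(NCCCN1CCN(CCCNc2ccnc3cc(Cl)ccc23)CC1)c1cccc(C(F)(F)F)c1` gives 30100 nM; the step of a 7.7-fold higher number from compound 2 to compound 3 (0.89 log units; beyond the scatter) is the only measured step in the set.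

Compound 4 `O=C(CC1CCCCC1)NCCCN1CCN(CCCNc2ccnc3cc(Cl)ccc23)CC1` differs from compound 1 as follows: cyclohexyl in place of butyl on a saturated chain carbon bound to a carbonyl carbon. For the measured compounds named here, no measured step covers a change on a saturated chain carbon bound to a carbonyl carbon; the one step known, from an aryl amide to another aryl amide, does not bear on it. Going by the values given here, compound 1 has no value, so no size of step from compound 1 to compound 4 in this assay can be set. What can be said is that the two measured amides are compound 2, which gives 3900 nM, and compound 3, which gives 30100 nM.

Compound 4 is therefore expected to give about 10000 nM in this assay, with a range of 2000 nM to 50000 nM.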

Compound 4, half-maximal inhibitory concentration: 7200 nM
Beside the measured number, compound 4's estimate is 1.4-fold (0.14 log units) above it, and the stated range covers the measured number.
By their numbers in this assay, from the lowest: compounds 2 and 4 (each within the scatter of the next); then compound 3.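

With compound 4, a saturated tail on the amide carbonyl carbon now has a number in this assay, and cyclohexylmethyl gives a 4.2-fold lower number from compound 3 to compound 4 (0.62 log units; beyond the scatter), while a 1.8-fold higher number from compound 2 to compound 4 (0.27 log units; within the scatter) stays within the scatter. An aromatic ring in the tail therefore does not fix the read-out by itself: compound 2 and compound 4 cannot be told apart, although one carries 4-ethylphenyl and the other cyclohexylmethyl, and compound 3 alone stands apart at the high end. No measurement in hand explains this difference between the tails.

Compound 1 has no number, so the change from butyl to cyclohexyl on the saturated chain carbon bound to a carbonyl carbon cannot be read as a step. As far as these compounds go, how a tail ending in an amine or a carboxylic acid would read remains open.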